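Bromo added to the fluorophenyl aniline of compound 3

A few compounds are considered here, and "the series" means these few. Any claim that something is new, unique, unknown or untested is made for them only; others in the source may bear on it.

The shared core of this series carries an aniline on its aromatic nitrogen and a chain ending in a sulfonamide-bearing anilide. Compound 1 `COc1cc2ncnc(Nc3ccc(Cl)c(C(F)(F)F)c3)c2cc1OCCCCC(=O)Nc1ccc(S(N)(=O)=O)cc1` and compound 2 `C#Cc1cccc(Nc2ncnc3cc(OC)c(OCCCCC(=O)Nc4ccc(S(N)(=O)=O)cc4)cc23)c1` carry the larger anilines; in a functional assay on A549 cells (Homo sapiens) for antiproliferative activity, read by MTT assay, with a stated time of 72 h (a higher number here means a weaker inhibitor, a lower number a stronger inhibitor), compound 1 gives 9270 nM and compound 2 gives 7720 nM, with a 1.2-fold lower number from compound 1 to compound 2 (0.08 log units; within the scatter). Compound 3 `COc1cc2ncnc(Nc3ccc(F)cc3)c2cc1OCCCCC(=O)Nc1ccc(S(N)(=O)=O)cc1` carries the bare 4-fluorophenyl. In this assay compound 3 returns only a limit, > 40000 nM, so its position on the scale is known just as the boundary (the limit of > 40000 nM in this assay, at which 1 of the 3 values shown sits). The two steps into compound 3 are therefore bounds as well: an at least 4.3-fold higher number from compound 1 to compound 3 (0.63 log units; beyond the scatter) and an at least 5.1-fold higher number from compound 2 to compound 3 (0.71 log units; beyond the scatter); both show that stripping the aniline back to 4-fluorophenyl costs activity.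

Compound 4 `COc1cc2ncnc(Nc3ccc(F)c(Br)c3)c2cc1OCCCCC(=O)Nc1ccc(S(N)(=O)=O)cc1` is the next step: bromo in place of hydrogen on an aromatic carbon. This runs against the direction of the two measured steps, putting a substituent back onto the ring meta to the large group, as in compound 1. Among the measured compounds shown here, compound 4 is therefore expected to improve on the limit by an at least 3.3-fold lower number from compound 3 to compound 4 (0.52 log units; beyond the scatter), the size uncertain since no measured pair shows bromo against hydrogen here. Compound 4 is expected at 12000 nM in this assay, within 5000 nM to 40000 nM.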

Compound 4, half-maximal inhibitory concentration: 16000 nM
Estimate against measurement, compound 4: 1.3-fold (0.12 log units) below; low and high end bracket the measured number.
By their numbers in this assay, from the lowest: compounds 2, 1 and 4 (each within the scatter of the next, the first and the last beyond it). At a limit, above all of these: compound 3.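

In this assay, a single bromo ortho to a fluoro group restores a measured value to an aniline that otherwise reaches only a limit, with an at least 2.5-fold lower number from compound 3 to compound 4 (0.39 log units; beyond the scatter); the size of this step is a bound and not a full measure: the limit of > 40000 nM in this assay, at which 1 of the 4 values shown sits.

Set against the larger anilines, the result differs by partner: a 1.7-fold higher number from compound 1 to compound 4 (0.24 log units; within the scatter), so 3-bromo-4-fluorophenyl and 4-chloro-3-(trifluoromethyl)phenyl cannot be separated here, while a 2.1-fold higher number from compound 2 to compound 4 (0.32 log units; beyond the scatter) leaves 3-ethynylphenyl the better of that pair. This position, meta to a large group, therefore matters for this read-out, and one added heavy atom there is enough to bring the 4-fluorophenyl aniline close to compound 1.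

Whether the gain is specific to bromo remains open, since the compounds shown do not tell it from chloro, methyl or methoxy at the same carbon, or from bromo without the neighbouring fluoro group. Also open, on these data alone, is how far the values depend on the chain and its sulfonamide end, which a shorter chain or a carboxylic acid in place of the sulfonamide would address.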